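Morpholine for Thiomorpholine on a Second Core

The compounds below may be only part of what the source reports. "The series", "measured", "known", "first", "only" and "open" are said of these compounds alone.

Three compounds have been measured in a functional assay on A-431 cells (Homo sapiens) for cytotoxicity, read by MTT assay, with a stated time of 72 h, tested at 3 uM; on this read-out higher numbers stand for more inhibition of growth at the one concentration tested and lower numbers for less inhibition of growth:

compound 1, `Cc1cccc(/C(N)=N/NC(=S)N2CCSCC2)n1`: 51.7%
compound 2, `Cc1cccc(/C(N)=N/NC(=S)N2CCOCC2)n1`: 45.8%
compound 3, `N/C(=N\NC(=S)N1CCSCC1)c1ccc(F)cn1`: 61.2%

Compound 1 and compound 2 share a core and differ in one place: morpholin-4-yl in place of thiomorpholin-4-yl on a thiocarbonyl carbon. This change produced a number 5.9 percentage points lower from compound 1 to compound 2 (within the scatter). Compound 3 carries a different core, and the difference between the two cores is not broken down here. Its value in this assay is the highest of the three, but compound 1 stands within the scatter of it, and only compound 2 lies beyond it.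

Compound 4, `N/C(=N\NC(=S)N1CCOCC1)c1ccc(F)cn1`, has not yet been measured. It relates to compound 3 as compound 2 relates to compound 1: morpholin-4-yl in place of thiomorpholin-4-yl on a thiocarbonyl carbon. The place of the change is the same in both pairs, a thiocarbonyl carbon whose other neighbour is an amide-type nitrogen, so this is the same change, now made on the core of compound 3. Within the data shown here, the only guide to its effect is the pair already measured, where the step stayed within the scatter. Compound 4 is expected to move by a number 6.2 percentage points lower from compound 3 to compound 4 (within the scatter) in this assay, a step that rests on a number 5.9 percentage points lower from compound 1 to compound 2 (within the scatter). For compound 4 the estimate in this assay is 55%, with a likely range from 42% to 68%.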

Compound 4, percent growth inhibition at one concentration: 47%
Estimate against measurement, compound 4: 8 percentage points above; measured number inside the range.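

Made on the second core, morpholin-4-yl in place of thiomorpholin-4-yl on a thiocarbonyl carbon gives a number 14.2 percentage points lower from compound 3 to compound 4 (beyond the scatter) in this assay. Set beside the earlier pair, the change lowers the number on both cores, and the two steps cannot be told apart in size, even though only the second lies beyond the scatter on its own: the same change on two cores in this assay, a number 5.9 percentage points lower (within the scatter) from compound 1 to compound 2 and a number 14.2 percentage points lower (beyond the scatter) from compound 3 to compound 4, 8.3 percentage points apart, within the scatter of two such steps. This supports carrying the change from the one core to the other as a step in the same direction, but it rests on just two pairs read at a single concentration, so it neither shows that the size of the step depends on the core nor establishes a rule for any further core in this series, and it gives no reason for the step.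

The compounds shown leave open whether another group on the thiocarbonyl carbon, such as piperidin-1-yl or an open-chain dimethylamino group, would stand nearer to thiomorpholin-4-yl or to morpholin-4-yl, and whether the step would hold on a third core. They also leave the difference between the two cores unresolved, as no compound shown separates its parts.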